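This account rests on a few compounds, and the source may have more. Where it says the series, first, only, none or still open, it means among the compounds named here.

Measured compounds:
compound 1 `COc1ccc([C@]2(CO)NC[C@@H](O)[C@@H]2O)cc1` — 395000 nM
compound 2 `COc1cccc([C@]2(CO)NC[C@@H](O)[C@@H]2O)c1` — 52000 nM

In an assay on isolated protein for inhibition of lysosomal alpha-glucosidase (Rattus norvegicus), read by colorimetric assay (on this read-out lower numbers stand for stronger inhibition and higher numbers for weaker inhibition), compound 2 gives 52000 nM, the lowest number of the two, and compound 1 gives 395000 nM, which lies beyond the scatter above compound 2. For the measured compounds named here, the two compounds differ in more than one place, so no single step between them is defined; only the two values are known.

Compound 3 `COc1ccc([C@]2(CO)NC[C@@H](O)[C@@H]2O)cc1OC` is the next compound in the series and has not yet been measured. The change from compound 2 is methoxy in place of hydrogen on an aromatic carbon. Compound 3 thereby combines the methoxy substitution pattern of compound 1 with that of compound 2. The step of a 2.1-fold higher number from compound 2 to compound 3 (0.33 log units; beyond the scatter) is expected to go toward a higher number, probably beyond the scatter, because compound 1 gives 395000 nM in this assay while sharing the methoxy that enters here. Compound 3 is estimated at 110000 nM, with a range of 35000 nM to 400000 nM.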

Compound 3, half-maximal inhibitory concentration: 105000 nM
The estimate for compound 3 lay 1.0-fold (0.02 log units) above the measured number, within the range that was stated.
By their numbers in this assay, from the lowest: compound 2; then compound 3; then compound 1.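

Read in this assay as a working result, methoxy in place of hydrogen, ortho to a methoxy group and para to a group of 9 heavy atoms, gives a 2.0-fold higher number from compound 2 to compound 3 (0.31 log units; beyond the scatter) on the way up from the singly substituted compound. The same kind of change gives a 3.8-fold lower number from compound 1 to compound 3 (0.58 log units; beyond the scatter) when it starts from the other singly substituted compound, so the direction of a methoxy step here depends on which methoxy is already present, and the two methoxy groups do not simply add up. Nothing at hand bears on the reason for this reversal.

Open, going by these compounds, is how the core with hydrogen in both places reads, which would give each methoxy a step of its own. Also open, on these data alone, is whether a hydroxyl, a chlorine or an ethoxy in the place of the entering methoxy would follow the same direction.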